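Trifluoromethyl for fluoro: working notes on a small series

A few compounds are considered here, and "the series" means these few. Any claim that something is new, unique, unknown or untested is made for them only; others in the source may bear on it.

Values in a functional assay on HepG2 cells (Homo sapiens) for antiproliferative activity, read by MTT assay, with a stated time of 24 h (on this read-out higher numbers stand for weaker inhibition and lower numbers for stronger inhibition), for the measured compounds
- compound 1 `Cc1ccc(-c2nn(-c3ccccc3)cc2-c2nc3ccccc3n2S(=O)(=O)c2ccc(C(F)(F)F)cc2)cc1` gives 1930 nM
- compound 2 `O=S(=O)(c1ccc(C(F)(F)F)cc1)n1c(-c2cn(-c3ccccc3)nc2-c2ccc(F)cc2)nc2ccccc21` gives 1680 nM
- compound 3 `O=S(=O)(c1ccc(F)cc1)n1c(-c2cn(-c3ccccc3)nc2-c2ccc(C(F)(F)F)cc2)nc2ccccc21` gives 2730 nM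

The value of compound 3 lies within the usual scatter of the values of compound 1 and compound 2, so these numbers do not separate the three compounds. Compound 4 `O=S(=O)(c1ccc(C(F)(F)F)cc1)n1c(-c2cn(-c3ccccc3)nc2-c2ccc(C(F)(F)F)cc2)nc2ccccc21` differs from compound 3 by trifluoromethyl in place of fluoro on an aromatic carbon and this is trifluoromethyl in place of fluoro on an aromatic carbon, para to a large group. This exchange has not been measured anywhere in the series. Among the compounds with values here, the only measured step is a 1.1-fold lower number from compound 1 to compound 2 (0.06 log units; within the scatter) for a different exchange, fluoro in place of methyl on an aromatic carbon, and it lies within the scatter. It therefore offers only weak guidance, and it gives no sign of a large response to a single substituent exchange. No step beyond the scatter is expected in this assay and the data support no firm direction. The estimated change is a 1.3-fold lower number from compound 3 to compound 4 (0.11 log units; within the scatter) and it is expected to stay within the scatter. For compound 4 the expected value is 2100 nM with an estimated range from 1000 nM to 4200 nM as the span for a single measurement.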

Compound 4, half-maximal inhibitory concentration: 1120 nM
The estimate for compound 4 lay 1.9-fold (0.27 log units) above the measured number; the measured number falls inside the stated range.
By their numbers in this assay, from the lowest: compounds 4, 2, 1 and 3 (each within the scatter of the next, the first and the last beyond it).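

In this assay, within the data shown here, the change from 4-fluorophenyl to 4-(trifluoromethyl)phenyl gives the first step beyond the scatter, modest in size (a 2.4-fold lower number from compound 3 to compound 4 (0.39 log units; beyond the scatter)). This shows that a single substituent exchange on this aromatic carbon, para to a large group, can register in this assay, which the earlier step within the scatter gave no sign of. At the other substituted place of the shared core, neither the same exchange (a 1.5-fold lower number from compound 2 to compound 4 (0.18 log units; within the scatter)) nor trifluoromethyl in place of methyl (a 1.7-fold lower number from compound 1 to compound 4 (0.24 log units; within the scatter)) gets beyond the scatter, so among these compounds only the first place gives a readable response, and nothing at hand gives a reason for it.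

The compounds shown carry only fluoro and trifluoromethyl at the place with the readable step, so it remains open how a nitrile, a methoxy group, an amine or a carboxylic acid would read there. On these data alone, with a single step beyond the scatter, it also remains open whether the numbers follow any ordering of substituents at this place or whether this is an isolated pair.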